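This account rests on a few compounds, and the source may have more. Where it says the series, first, only, none or still open, it means among the compounds named here.

Compound 1 `Cc1cccc(-c2c(N)n[nH]c2C)c1`: > 100000 nM
Compound 2 `Cc1[nH]nc(N)c1-c1cccc(Cl)c1`: > 100000 nM

In an assay on Sf9 cells for inhibition of mitogen-activated protein kinase kinase kinase 14 (Homo sapiens), read by ADP-Glo, with a stated time of 60 min (on this read-out higher numbers stand for weaker inhibition and lower numbers for stronger inhibition), compound 1 gives > 100000 nM, which is a limit of the assay and not a number. In this assay compound 2 gives > 100000 nM, likewise a limit. The step that the two limits leave unreadable from compound 1 to compound 2 therefore cannot be read. Compound 2 stands at the limit (the limit of > 100000 nM in this assay, at which 2 of the 2 values shown sit), so its true value is not known, only that it lies at or past this boundary.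

Compound 3 `Cc1[nH]nc(N)c1-c1cccc(Br)c1` differs from compound 2 by bromo in place of chloro on an aromatic carbon. The only measured step that touches this part of the molecule is the one from compound 1 to compound 2, and its size is unreadable, so no direction beyond the scatter can be drawn for this assay from the numbers shown.

Compound 3 is therefore expected to sit at about 150000 nM, within 30000 nM to 1000000 nM. The expected step that the limit leaves unreadable from compound 2 to compound 3 is thus no change beyond the scatter.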

Compound 3, half-maximal inhibitory concentration: > 100000 nM
Compound 3 gave a limit, no number; the forecaster's own chance of this, stated with the estimate: 85%; the middle value lies beyond the limit too.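

In this assay compound 3 gives > 100000 nM, a limit and not a number, so the steps linking compound 1, compound 2 and compound 3 cannot be read. The compounds shown leave open whether methyl, chloro or bromo differ at all on this read-out: the limit of > 100000 nM in this assay, at which 3 of the 3 values shown sit.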